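The source may report more compounds than this note shows. Statements on the series, on what has been measured and on what is new or still open speak of the compounds shown alone.

Measured compounds:
compound 1, `CCCC(=O)N1CCC(NS(=O)(=O)c2ccc(NC(=O)CC3CCCC3)c3ccccc23)CC1`, 145 nM
compound 2, `CCCC(=O)N1CCC(NS(=O)(=O)c2ccc(NC(=O)c3ccc(CC)cc3)c3ccccc23)CC1`, 10.8 nM

Of the compounds shown here, two have been measured in an in vitro functional assay on CHO/Galpha16 cells for antagonist activity at C-C chemokine receptor type 8 (Homo sapiens), read by FLIPR; a lower number here means a stronger inhibitor, a higher number a weaker inhibitor. Among the compounds with values here, compound 2 holds the lower of the two numbers, so on this small set it is the stronger inhibitor; the only neighbour for comparison is compound 1, and the step of a 13-fold lower number from compound 1 to compound 2 (1.13 log units; beyond the scatter) separates them, a change that lies well beyond the scatter of the measurement.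

Compound 3, `CCCC(=O)N1CCC(NS(=O)(=O)c2ccc(NC(=O)c3ccccn3)c3ccccc23)CC1`, has not yet been measured. Its change from compound 2 is pyridin-2-yl in place of 4-ethylphenyl on a carbonyl carbon. Within the data shown here, the one measured step that bears on this position, from compound 1 to compound 2, shows that exchanging the group on this carbonyl carbon can move the number a great deal. Compound 3 keeps a six-membered aromatic ring at that place, but loses the ethyl chain of compound 2 and gains a ring nitrogen. The expectation is therefore a moderately higher number than compound 2, a step of about a 5.6-fold higher number from compound 2 to compound 3 (0.74 log units; beyond the scatter), with wide uncertainty because the aromatic ring is kept. The estimated value for compound 3 in this assay is 60 nM, expected between 15 nM and 250 nM.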

Compound 3, half-maximal inhibitory concentration: 41.7 nM
Beside the measured number, compound 3's estimate is 1.4-fold (0.16 log units) above it; the range from low to high includes it.
By their numbers in this assay, from the lowest: compound 2; then compound 3; then compound 1.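

In this assay the change to pyridin-2-yl on the carbonyl carbon gives a 3.9-fold higher number from compound 2 to compound 3 (0.59 log units; beyond the scatter) and so costs something beyond the scatter, yet the 4-ethylphenyl group is not needed for a number well under that of compound 1. Against the cyclopentylmethyl group, the same pyridin-2-yl gives a 3.5-fold lower number from compound 1 to compound 3 (0.54 log units; beyond the scatter) and this means that, among these three compounds, both groups with a six-membered aromatic ring give lower numbers than the group without one. Nothing available here accounts for this order of the three numbers.

On these data alone, the step to compound 3 removes the ethyl chain and brings in a ring nitrogen in one change, so the share of each in the step stays open; a plain phenyl ring on the same carbonyl carbon would separate the two. As far as these compounds go, it is also open how the number would respond to a longer chain in place of the ethyl group, or to a pyridin-3-yl or pyridin-4-yl group in place of pyridin-2-yl.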